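From a Ring-Held Acid to a Chain-Held Acid

A few compounds are considered here, and "the series" means these few. Any claim that something is new, unique, unknown or untested is made for them only; others in the source may bear on it.

Among the three measured compounds, compound 3 `O=C(O)C1CCC(c2ccc(OCc3ccc4ccccc4n3)cc2)C1` gives the lowest number in an assay on membranes from lung (Cavia porcellus) for binding affinity to cysteinyl leukotriene receptor (Homo sapiens) (a lower number here means a stronger inhibitor, a higher number a weaker inhibitor), with 43 nM. Compound 2 `c1ccc2nc(COc3ccc(OCCCc4nnn[nH]4)cc3)ccc2c1` gives 69 nM, and the step of a 1.6-fold lower number from compound 2 to compound 3 (0.21 log units; within the scatter). Compound 1 `O=C(O)CC1CCCC1Cc1ccc(OCc2ccc3ccccc3n2)cc1` gives 100 nM, a gap to compound 3 that lies beyond the scatter. Compound 4 `O=C(O)CCCOc1ccc(OCc2ccc3ccccc3n2)cc1` differs from compound 3 in one place: 3-carboxypropoxy in place of 3-carboxycyclopentyl on an aromatic carbon. Among the measured compounds shown here, no measured step swaps exactly these two groups, so the nearest guide is compound 2, whose 3-(1H-tetrazol-5-yl)propoxy group is, like the entering 3-carboxypropoxy, a chain rather than a ring, and whose value sits within the scatter of compound 3. The step is therefore expected to be small, a 2.3-fold higher number from compound 3 to compound 4 (0.37 log units; beyond the scatter). Compound 4 is estimated at 100 nM, within 40 nM to 300 nM.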

Compound 4, inhibition constant: 1200 nM
Compound 4: middle estimate off by 12-fold (1.08 log units), on the low side; measured number above the stated range.
By their numbers in this assay, from the lowest: compounds 3, 2 and 1 (each within the scatter of the next, the first and the last beyond it); then compound 4.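

Compound 2 and compound 3 stand within the scatter of each other, yet at this aromatic carbon a carboxy group cannot simply move from a ring to a chain: this assay shows a 28-fold higher number from compound 3 to compound 4 (1.45 log units; beyond the scatter), a large step. Keeping the chain does not settle it either, since carboxy in place of 1H-tetrazol-5-yl gives a 17-fold higher number from compound 2 to compound 4 (1.24 log units; beyond the scatter), so the group at the chain's end counts too. Nothing available explains either step. From the compounds shown here alone, whether a longer chain ending in carboxy, or an amide at the chain's end, would bring the number back down stays open.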